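Cytotoxicity notes on the step to compound 4

The source may hold more compounds than are shown below. What is called first, only, known or untested is meant among the compounds shown, and "the series" means these compounds.

Going by the values given here, in a toxicity assay (J774.1 cells) for cytotoxicity, with Mus musculus as the target, read by resazurin assay, with a stated time of 24 h (on this read-out lower numbers stand for stronger inhibition and higher numbers for weaker inhibition), compound 3 (`O=C(OCCCc1cccnc1)C1CCCCN1S(=O)(=O)Cc1cccc([N+](=O)[O-])c1`) gives 46700 nM as the only actual number so far. Compound 1 (`O=C(OCCO)C1CCCCN1S(=O)(=O)Cc1ccccc1`) reads > 100000 nM as a limit of the assay. Compound 2 (`CC(C)OC(=O)C1CCCCN1S(=O)(=O)Cc1ccccc1`) reads > 100000 nM as a limit too. Compound 4 (`CC(C)Nc1ccc(CS(=O)(=O)N2CCCCC2C(=O)OCCCc2cccnc2)cc1`) carries 4-(isopropylamino)phenyl in place of 3-nitrophenyl on a saturated chain carbon bound to a sulfonyl sulfur as its change. The step that the two limits leave unreadable from compound 1 to compound 2 is the only measured one, lies at another place and gives no size to carry over. Compound 3 at 46700 nM therefore remains the sole anchor for the estimate. The expectation is a 1.2-fold lower number from compound 3 to compound 4 (0.07 log units; within the scatter) with no direction favoured and an estimated size within the usual scatter. For compound 4 the expected value is 40000 nM with an estimated range from 15000 nM to 100000 nM for now.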

Compound 4, half-maximal inhibitory concentration: 44300 nM
Compound 4: the middle estimate sits 1.1-fold (0.04 log units) below what was measured, and the stated range covers the measured number.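

In this assay, going by these compounds alone, the change gives a 1.1-fold lower number from compound 3 to compound 4 (0.02 log units; within the scatter) as the first readable step, and that step lies within the scatter. On a saturated chain carbon bound to a sulfonyl sulfur, 4-(isopropylamino)phenyl thus reads the same as 3-nitrophenyl, although a hydrogen-bond donor enters with it. On these data alone, whether 4-aminophenyl or 4-carboxyphenyl at this place would give a step beyond the scatter stays open. The step from compound 1 to compound 2 cannot be read, and with it any comparison of the two places of change: the limit of > 100000 nM in this assay, at which 2 of the 4 values shown sit.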